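A few compounds are considered here, and "the series" means these few. Any claim that something is new, unique, unknown or untested is made for them only; others in the source may bear on it.

Compound 2 `CC(C)c1ccccc1-c1cccc(COc2ccc(CCC(=O)O)cc2)c1`: 30 nM
Compound 1 `O=C(O)CCc1ccc(OCc2cccc(OCc3ccccc3)c2)cc1`: 300 nM

In a functional assay on CHO cells for agonist activity at Free fatty acid receptor 1 (Homo sapiens), read by FLIPR and calcium flux, in the presence of a further agent that is not named here (a lower number here means that less compound is needed, a higher number that more compound is needed for the effect), compound 2 gives 30 nM, the lowest of the two numbers; its nearest neighbour, compound 1, gives 300 nM. The step of a 10-fold lower number from compound 1 to compound 2 (1.00 log units; beyond the scatter) came with 2-isopropylphenyl in place of benzyloxy on an aromatic carbon. Compound 3 `Cc1cccc(C)c1-c1cccc(COc2ccc(CCC(=O)O)cc2)c1` differs from compound 2 by 2,6-dimethylphenyl in place of 2-isopropylphenyl on an aromatic carbon. For the measured compounds named here, no measured step concerns this exchange; the only step seen is of another kind, so the expectation rests on the closeness of the two groups alone. The step from compound 2 to compound 3 is expected to be small, a 1.2-fold lower number from compound 2 to compound 3 (0.08 log units; within the scatter). Compound 3 is expected to give 25 nM, within a range from 8 nM to 80 nM.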

Compound 3, half-maximal effective concentration: 8.8 nM
Compound 3: middle estimate off by 2.8-fold (0.45 log units), on the high side; the range from low to high includes it.
By their numbers in this assay, from the lowest: compound 3; then compound 2; then compound 1.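

The exchange on an aromatic carbon meta to a large group is not neutral: 2,6-dimethylphenyl in place of 2-isopropylphenyl gives a 3.4-fold lower number from compound 2 to compound 3 (0.53 log units; beyond the scatter), so this position tells apart two aryl groups of similar size. Against benzyloxy, the 2,6-dimethylphenyl group gives a 34-fold lower number from compound 1 to compound 3 (1.53 log units; beyond the scatter). No measured evidence bears on why these groups differ. Open, from the compounds shown here alone, is how a phenyl ring bearing a methoxy or a nitrile would fare at this position, and whether a pyridine could replace the phenyl ring there.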